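Trifluoromethyl for cyano in a chlorinated compound

The source may hold more compounds than are shown below. What is called first, only, known or untested is meant among the compounds shown, and "the series" means these compounds.

In a toxicity assay on Huh-7.5 cells (Homo sapiens) for cytotoxicity, read by MTT assay, with a stated time of 96 h (on this read-out higher numbers stand for lower toxicity in this test and lower numbers for higher toxicity in this test), compound 1 (`CN(C)CCN(C)c1ccc(C#N)c(CN2CCN(C(c3ccccc3)c3ccccc3)CC2)c1`) gives > 20000 nM as a limit of the assay, not a number. Compound 2 (`CN(C)CCN(C)c1ccc(C#N)c(CN2CCN(C(c3ccccc3)c3ccc(Cl)cc3)CC2)c1`) gives 5660 nM and compound 3 (`CN(C)CCN(C)c1ccc(C#N)c(CN2CCN([C@H](c3ccccc3)c3ccc(Cl)cc3)CC2)c1`), the same atoms and bonds with a configuration drawn, gives 8230 nM as its value. These two stand level (a 1.5-fold higher number from compound 2 to compound 3 (0.16 log units; within the scatter)) and are the only true numbers shown. Chloro in place of hydrogen on an aromatic carbon gave two steps (an at least 3.5-fold lower number from compound 1 to compound 2 (0.54 log units; beyond the scatter)) (an at least 2.4-fold lower number from compound 1 to compound 3 (0.38 log units; beyond the scatter)) but left the cyano alone. Compound 4 (`CN(C)CCN(C)c1ccc(C(F)(F)F)c(CN2CCN(C(c3ccccc3)c3ccc(Cl)cc3)CC2)c1`) carries trifluoromethyl in place of cyano on an aromatic carbon. Among the measured compounds shown here, no measured step changes the cyano, so compound 2 at 5660 nM remains the anchor for the expectation. The expected step lies within the scatter (a 1.1-fold lower number from compound 2 to compound 4 (0.05 log units; within the scatter)). For compound 4 the estimated value is 5000 nM with an expected range from 2000 nM to 12000 nM in this estimate.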

Compound 4, half-maximal cytotoxic concentration: 6960 nM
For compound 4 the middle estimate is 1.4-fold (0.14 log units) below the measured one; low and high end bracket the measured number.
By their numbers in this assay, from the lowest: compounds 2, 4 and 3 (each within the scatter of the next). At a limit, above all of these: compound 1.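

On the aromatic carbon para to the (2-(dimethylamino)ethyl)(methyl)amino group, trifluoromethyl in place of cyano makes no readable difference in this assay (a 1.2-fold higher number from compound 2 to compound 4 (0.09 log units; within the scatter)). The earlier compounds shown here changed only the chloro and the drawn configuration, whereas this pair shows that the cyano can give way to a larger group without a hydrogen-bond acceptor and the toxicity reading holds level. Nothing shown here gives a reason for this result.

As far as these compounds go, whether an amine or a carboxylic acid at this place would read the same remains open. So does whether the swap behaves alike in the compound without chloro.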